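A 2-Fluorophenyl Amide After Two Close Fluorophenyl Neighbours

A few compounds are considered here, and "the series" means these few. Any claim that something is new, unique, unknown or untested is made for them only; others in the source may bear on it.

Two fluorophenyl amides on a shared core have been measured so far. In a functional assay on SiHa cells (Homo sapiens) for inhibition, read by CCK-8 assay, with a stated time of 72 h, tested at 1 uM (a higher number here means more inhibition of growth at the concentration tested, a lower number less inhibition of growth), compound 1 `CN(C)C(=O)c1cc2cnc(Nc3ccc(NC(=O)C4(C(=O)Nc5ccc(F)cc5)CC4)cc3)nc2n1C1CCCC1` gives 36.5%, and compound 2 `CN(C)C(=O)c1cc2cnc(Nc3ccc(NC(=O)C4(C(=O)Nc5cccc(F)c5)CC4)cc3)nc2n1C1CCCC1` gives 29.7%. For the measured compounds named here, compound 2 therefore stands within the scatter of compound 1, the only other measured compound, and the two cannot be separated on these numbers.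

The next compound, compound 3 `CN(C)C(=O)c1cc2cnc(Nc3ccc(NC(=O)C4(C(=O)Nc5ccccc5F)CC4)cc3)nc2n1C1CCCC1`, has the same atoms as compound 2, joined differently: 2-fluorophenyl in place of 3-fluorophenyl on an amide-type nitrogen. In words, a 2-fluorophenyl stands in place of a 3-fluorophenyl on an amide-type nitrogen.

Going by the values given here, one measured step bears on this change. It concerns the same amide-type nitrogen, where 3-fluorophenyl replaced 4-fluorophenyl, and it amounts to a number 6.8 percentage points lower from compound 1 to compound 2 (within the scatter). Among the compounds with values here, no measured compound yet carries the 2-fluorophenyl, so this single small step is a limited guide, and no shift beyond the scatter is expected in this assay. The expected change is a number 2.3 percentage points higher from compound 2 to compound 3 (within the scatter), with no firm direction. For compound 3 the estimated value is 32%, with an expected range of 20% to 45%.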

Compound 3, percent growth inhibition at one concentration: 63.4%
Compound 3: middle estimate off by 31.4 percentage points, on the low side; measured number above the stated range.
By their numbers in this assay, from the lowest: compounds 2 and 1 (each within the scatter of the next); then compound 3.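

In this assay the amide-type nitrogen proves sensitive to which fluorophenyl it carries: 2-fluorophenyl in place of 3-fluorophenyl gives a number 33.7 percentage points higher from compound 2 to compound 3 (beyond the scatter) and, in place of 4-fluorophenyl, gives a number 26.9 percentage points higher from compound 1 to compound 3 (beyond the scatter) on the same scale. The earlier exchange of 4-fluorophenyl for 3-fluorophenyl, at a number 6.8 percentage points lower from compound 1 to compound 2 (within the scatter) in size, had shown no separation, so this is the first step at this place to stand clear of the scatter, and it comes from groups with the same atoms joined differently, leaving compound 3 apart from both neighbours. Nothing at hand speaks to why the 2-fluorophenyl stands apart from the other two.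

The compounds shown leave open whether the gain belongs to fluorine itself or would also appear with another group in its place, such as a 2-chlorophenyl, a 2-methylphenyl or a 2-methoxyphenyl, or with a plain phenyl as the reference. They also leave open whether the gap seen for compound 3 at this single tested concentration would hold across a full concentration range or in other cell lines.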